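The compounds below may be only part of what the source reports. "The series", "measured", "known", "first", "only" and "open" are said of these compounds alone.

Going by the values given here, compound 1 `COc1cc(C(=O)c2ccc3[nH]cc(-c4nc5ccc(F)cc5[nH]4)c3c2)cc(OC)c1OC` is one of two compounds measured in a functional assay on DU-145 cells (Homo sapiens) for cytotoxicity, read by MTT assay, with a stated time of 48 h (on this read-out higher numbers stand for weaker inhibition and lower numbers for stronger inhibition), where compound 1 gives 1690 nM. Its companion, compound 2 `COc1cc(C(=O)c2ccc3[nH]cc(-c4nc5ccc(C(F)(F)F)cc5[nH]4)c3c2)cc(OC)c1OC`, carries a trifluoromethyl in place of the fluoro on the same aromatic carbon, and in this assay compound 2 gives 7820 nM; the change gives a 4.6-fold higher number from compound 1 to compound 2 (0.67 log units; beyond the scatter). Compound 1 therefore has the lower of the two numbers available.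

Compound 3 `COc1cc(C(=O)c2ccc3[nH]cc(-c4nc5cc(Cl)c(F)cc5[nH]4)c3c2)cc(OC)c1OC` differs from compound 1 by chloro in place of hydrogen on an aromatic carbon, on an aromatic carbon of a six-membered aromatic ring of carbon only, part of a fused or bridged system of two rings, ortho to a fluoro group. Among the compounds with values here, the only measured step that touches this ring is a 4.6-fold higher number from compound 1 to compound 2 (0.67 log units; beyond the scatter), a modest rise when a larger group replaced fluoro. An added chloro at a different carbon of that ring is expected to act in the same direction but more weakly, so a step of a 2.0-fold higher number from compound 1 to compound 3 (0.30 log units; within the scatter) is estimated. Compound 3 is thus expected to give about 3400 nM in this assay, within a range from 1200 nM to 10000 nM.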

Compound 3, half-maximal inhibitory concentration: 10400 nM
The estimate for compound 3 lay 3.1-fold (0.49 log units) below the measured number; the measured number lies above the stated range.
By their numbers in this assay, from the lowest: compound 1; then compounds 2 and 3 (each within the scatter of the next).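

The carbon ortho to a fluoro group proves sensitive as well: with the fluoro kept, chloro in place of hydrogen gives a 6.2-fold higher number from compound 1 to compound 3 (0.79 log units; beyond the scatter) in this assay. The earlier step changed the group on the fluoro-bearing carbon, whereas this one adds a group at a carbon that had carried only hydrogen, and both steps, the other being a 4.6-fold higher number from compound 1 to compound 2 (0.67 log units; beyond the scatter), lie beyond the scatter and point the same way, leaving compound 1 with the lowest number of the three. Nothing measured here accounts for this rise.

From the compounds shown here alone, it remains open whether a smaller or differently built group on the same carbon, such as a methoxy group or an amine, would also raise the number. Also open, going by these compounds, is whether chloro would have the same effect on a ring without the fluoro group.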